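The source may report more compounds than this note shows. Statements on the series, on what has been measured and on what is new or still open speak of the compounds shown alone.

Measured so far:
compound 1 `Oc1cccc(-c2cc(-c3cccs3)cc(-c3ccccc3O)n2)c1` — in a functional assay on T47D cells (Homo sapiens) for cytotoxicity, read by CCK-8 assay (on this read-out higher numbers stand for weaker inhibition and lower numbers for stronger inhibition), compound 1 gives > 50000 nM, a limit of the assay rather than a number.
compound 2 `Oc1ccccc1-c1cc(-c2ccsc2)cc(-c2ccccc2O)n1` — in this assay compound 2 gives > 50000 nM, likewise only a limit of the assay.

Among the compounds with values here, compound 2 thus stands nowhere on a numerical scale: only a limit is known for it, and the one other value shown is also a limit. Both values sit at the limit of > 50000 nM in this assay, at which 2 of the 2 values shown sit. Within the data shown here, no step between measured compounds is available, so nothing about the size of any change has yet been measured.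

Compound 3 `Oc1cccc(-c2cc(-c3ccsc3)cc(-c3ccccc3O)n2)c1` differs from compound 2 by 3-hydroxyphenyl in place of 2-hydroxyphenyl on an aromatic carbon. The expectation for compound 3 rests on compound 2, whose > 50000 nM is a limit. It also leans on compound 1, which carries a 3-hydroxyphenyl group and whose > 50000 nM is a limit as well. The expected step in this assay is a step that the limit leaves unreadable from compound 2 to compound 3, meaning none beyond the usual scatter. Compound 3 is therefore estimated at 60000 nM, within 20000 nM to 200000 nM, and most likely reported again as a limit.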

Compound 3, half-maximal inhibitory concentration: > 50000 nM
Compound 3: a limit, no number; the forecaster's own chance of this, stated with the estimate: 80%; the middle value is on the limit's open side.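

In this assay compound 3 gives > 50000 nM, a limit of the assay and not a number. The steps to compound 3 from compound 2 and from compound 1 cannot be read, because every value is a limit: the limit of > 50000 nM in this assay, at which 3 of the 3 values shown sit.

The compounds shown leave open whether any change on the shared core gives a measurable value in this assay.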